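Capping the phenol: what a methyl should change

The source may hold more compounds than are shown below. What is called first, only, known or untested is meant among the compounds shown, and "the series" means these compounds.

Compound 1 `O=C(Nc1ccccc1)c1c(NO)cc(-c2ccccc2)oc1=O` carries a plain phenyl amide on the shared core. In an ADME assay on Huh-7 cells (Homo sapiens) for cytotoxicity, read by a luciferase reporter and WST assay, with a stated time of 3 days (on this read-out higher numbers stand for lower toxicity in this test and lower numbers for higher toxicity in this test), compound 1 gives 11600 nM. Compound 2 `O=C(Nc1ccc(F)cc1)c1c(NO)cc(-c2ccccc2)oc1=O` adds a fluoro to that phenyl; in this assay compound 2 reaches only a limit of the test, > 20000 nM. Compound 3 `O=C(Nc1ccc(O)cc1)c1c(NO)cc(-c2ccccc2)oc1=O` carries a hydroxy instead; in this assay compound 3 likewise stops at a limit, > 20000 nM. Compound 3 therefore stands where the test stops counting, at the limit of > 20000 nM in this assay, at which 2 of the 3 values shown sit. The two readable steps, an at least 1.7-fold higher number from compound 1 to compound 2 (0.23 log units; that floor lies within the scatter) and an at least 1.7-fold higher number from compound 1 to compound 3 (0.23 log units; that floor lies within the scatter), both point toward lower toxicity, yet each floor lies within the scatter, and a step that the two limits leave unreadable from compound 2 to compound 3 cannot be sized at all.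

Compound 4 `COc1ccc(NC(=O)c2c(NO)cc(-c3ccccc3)oc2=O)cc1` differs from compound 3 by methyl in place of hydrogen on an oxygen on an aromatic ring, which in the wider view turns hydroxy into methoxy and the 4-hydroxyphenyl into a 4-methoxyphenyl. Among the compounds with values here, no measured step covers such a swap on the amide phenyl; what is known is only that neither the fluoro nor the hydroxy compound returned a number. The step that the limit leaves unreadable from compound 3 to compound 4 is thus expected to stay within the scatter. Compound 4 is expected to land near 25000 nM, within a range from 12000 nM to 60000 nM, most likely again as a limit rather than a number.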

Compound 4, half-maximal cytotoxic concentration: > 20000 nM
Compound 4 ended at the assay's limit; the forecaster's own chance of this, stated with the estimate: 70%; the middle value is on the limit's open side.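

Replacing the hydrogen on the oxygen with a methyl does not bring the compound back into the countable range of this assay, so the hydroxy, the fluoro and now the methoxy on the amide phenyl all end at the same limit: the limit of > 20000 nM in this assay, at which 3 of the 4 values shown sit.

Within the data shown here, the only step with any size is an at least 1.7-fold higher number from compound 1 to compound 4 (0.23 log units; that floor lies within the scatter). Among these compounds, it points the same way as the earlier steps away from the plain phenyl of compound 1, but as a floor it cannot establish a real difference. The steps linking compound 4 to compound 2 and to compound 3 cannot be read, so the methyl itself has no measured effect here, only a result that stays at the limit.

Going by these compounds, how far compounds 2, 3 and 4 lie beyond that limit remains open, as does whether they differ from one another at all. On these data alone, it is also open whether a different group on the amide phenyl, such as an amine or a carboxylic acid, or a longer chain on the oxygen, such as ethoxy, would give a real number in this assay.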